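A few compounds are considered here, and "the series" means these few. Any claim that something is new, unique, unknown or untested is made for them only; others in the source may bear on it.

Compound 1 `COc1ccc(/C=N/NC(=S)NC(C)(C)[C@H]2CC=C(C)CC2)cc1` and compound 2 `CC1=CC[C@H](C(C)(C)NC(=S)N/N=C/c2ccc(O)cc2)CC1` form the measured pair. In a functional assay on 786-0 cells (Homo sapiens) for inhibition, read by sulforhodamine B assay, with a stated time of 48 h (on this read-out lower numbers stand for stronger inhibition of growth and higher numbers for weaker inhibition of growth), compound 1 gives 29600 nM. In this assay compound 2 gives > 100000 nM, which is a limit of the assay and not a number. Going by the values given here, compound 2 thus stands at the limit of > 100000 nM in this assay, at which 1 of the 2 values shown sits, and the only measured step is an at least 3.3-fold higher number from compound 1 to compound 2 (0.52 log units; beyond the scatter). Compound 3 `CC1=CC[C@H](C(C)(C)NC(=S)N/N=C/c2ccccc2O)CC1` differs from compound 2 by 2-hydroxyphenyl in place of 4-hydroxyphenyl on a carbon with a double bond to nitrogen. No measured step tests a change of this kind: the one step shown concerns the methyl on the oxygen, not the place of the hydroxyl, so no direction can be read from it. Compound 3 is expected near 70000 nM, within 20000 nM to 200000 nM, an expected step of an at least 1.4-fold lower number from compound 2 to compound 3 (0.15 log units; that floor lies within the scatter) that rests on little.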

Compound 3, concentration for total growth inhibition: 12100 nM
Compound 3: middle estimate off by 5.8-fold (0.76 log units), on the high side; the whole stated range lies above it.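

In this assay, 2-hydroxyphenyl in place of 4-hydroxyphenyl gives an at least 8.2-fold lower number from compound 2 to compound 3 (0.91 log units; beyond the scatter), so the place of the hydroxyl on the aromatic ring matters, which the step at the methyl on the oxygen could not show. The same group in place of 4-methoxyphenyl gives a 2.4-fold lower number from compound 1 to compound 3 (0.39 log units; beyond the scatter), so compound 3 also exceeds the earlier measured compound. The value for compound 2 is a limit of the assay: the limit of > 100000 nM in this assay, at which 1 of the 3 values shown sits.

The compounds shown leave open whether a methyl on the oxygen of 2-hydroxyphenyl would keep this growth inhibition. They also leave open whether an amine or a carboxylic acid could stand in place of that hydroxyl.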